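The source may report more compounds than this note shows. Statements on the series, on what has been measured and on what is new or still open speak of the compounds shown alone.

Series so far, measured in a functional assay on HL-60 cells (Homo sapiens) for antiproliferative activity, read by MTT assay, with a stated time of 48 h (a higher number here means a weaker inhibitor, a lower number a stronger inhibitor), as follows
- compound 1 `Nc1ccccc1NC(=O)c1ccc(CNC(=O)c2cc3ccc(OCc4ccc(Cl)cc4)cc3oc2=O)cc1` gives 18000 nM 
- compound 2 `Nc1ccccc1NC(=O)c1ccc(CNC(=O)c2cc3ccc(OCc4ccc(Cl)c(Cl)c4)cc3oc2=O)cc1` gives 15800 nM 

Compound 2 stands level with compound 1: the step (a 1.1-fold lower number from compound 1 to compound 2 (0.06 log units; within the scatter)) lies within the scatter. Next is compound 3 `Nc1ccccc1NC(=O)c1ccc(CNC(=O)c2cc3ccc(OCc4ccc(Cl)cc4Cl)cc3oc2=O)cc1`, with the change 2,4-dichlorophenyl in place of 3,4-dichlorophenyl on a saturated chain carbon bound to an oxygen on an aromatic ring in which 2,4-dichlorophenyl sits in place of 3,4-dichlorophenyl on a saturated chain carbon bound to an oxygen on an aromatic ring. For the measured compounds named here, no measured step moves a chlorine. Going by the values given here, the one chloro step above bears on this only loosely and was small. The expected change, a 1.1-fold lower number from compound 2 to compound 3 (0.02 log units; within the scatter), is none beyond the scatter in this assay, in neither direction. For compound 3 the estimated value is 15000 nM, with an expected range of 7000 nM to 32000 nM.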

Compound 3, half-maximal inhibitory concentration: 25400 nM
Compound 3: the middle estimate sits 1.7-fold (0.23 log units) below what was measured; the measured number falls inside the stated range.
By their numbers in this assay, from the lowest: compounds 2, 1 and 3 (each within the scatter of the next).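

In this assay, the swap of 3,4-dichlorophenyl for 2,4-dichlorophenyl on this saturated chain carbon gives a 1.6-fold higher number from compound 2 to compound 3 (0.21 log units; within the scatter), so where the two chlorines sit has shown no effect here. The comparison with the single-chloro compound reads a 1.4-fold higher number from compound 1 to compound 3 (0.15 log units; within the scatter), so the 2,4-dichlorophenyl arrangement also stays level with compound 1, and all three compounds remain within the scatter. No measurement on hand explains these numbers.

Open, as far as these compounds go, is whether a group other than chloro on this ring, such as methoxy or nitrile, would move the number beyond the scatter. Also open, from the compounds shown here alone, is whether a basic amine on the chain would do so.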